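A few compounds are considered here, and "the series" means these few. Any claim that something is new, unique, unknown or untested is made for them only; others in the source may bear on it.

Compound 2 `O=C(CCCCCCc1ccccc1)c1ncc(I)o1` stands at the lower of the two numbers recorded in an assay (Rattus norvegicus) for inhibition of Fatty-acid amide hydrolase 1 (Homo sapiens) (a higher number here means a weaker inhibitor, a lower number a stronger inhibitor), where compound 2 gives 3 nM. Going by the values given here, the only other measured compound is compound 1 `O=C(CCCCCCc1ccccc1)c1ncc(-c2ccc([N+](=O)[O-])cc2)o1`, which in this assay gives 50 nM. Among the compounds with values here, the one step between them, a 17-fold lower number from compound 1 to compound 2 (1.22 log units; beyond the scatter), shows that the small halogen at this position of the shared core gives a much lower number than the 4-nitrophenyl group.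

Compound 3 `O=C(CCCCCCc1ccccc1)c1ncc(Cl)o1` is the next compound to be measured. It differs from compound 2 by chloro in place of iodo on an aromatic carbon. No measured step exchanges one halogen for another, so the single step shown, a 17-fold lower number from compound 1 to compound 2 (1.22 log units; beyond the scatter), bears on this change only indirectly: it tells that a halogen at this carbon is compatible with a low number, but not how chloro compares with iodo. With nothing in the data pointing either way, the expected step of a 2.0-fold higher number from compound 2 to compound 3 (0.30 log units; within the scatter) is small, within or near the scatter. Compound 3 is therefore expected to give about 6 nM in this assay, with a range from 2 nM to 20 nM.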

Compound 3, inhibition constant: 5 nM
The estimate for compound 3 lay 1.2-fold (0.08 log units) above the measured number, and the stated range covers the measured number.
By their numbers in this assay, from the lowest: compounds 2 and 3 (each within the scatter of the next); then compound 1.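

In this assay the exchange of iodo for chloro on this aromatic carbon, next to the ring oxygen, gives a 1.7-fold higher number from compound 2 to compound 3 (0.22 log units; within the scatter) and so leaves the two halogens indistinguishable at this position. The earlier step rested on iodo alone, whereas a second halogen now also stands clear of the 4-nitrophenyl group, with a 10-fold lower number from compound 1 to compound 3 (1.00 log units; beyond the scatter), so the low number at this carbon is not tied to iodo in particular. Nothing beyond these numbers bears on why the two halogens read alike here.

Whether fluoro or bromo on this carbon, or a plain hydrogen, a methyl or an amine in the same place, keeps the number as low remains open in the compounds shown. They also leave open whether an unsubstituted phenyl falls nearer the halogens or nearer compound 1, and whether chloro and iodo still read alike when the chain on the carbonyl is shorter or longer.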